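A 4-Methylpiperidine Analogue on the Thiocarbonyl Carbon

The source may hold more compounds than are shown below. What is called first, only, known or untested is meant among the compounds shown, and "the series" means these compounds.

Compound 2 `CCN(Cc1ccncc1)C(=S)SCc1ccc(C(=O)Nc2ccccc2N)cc1` was tested in a functional assay on HeLa cells (Homo sapiens) for antiproliferative activity, read by CCK-8 assay, with a stated time of 72 h, tested at 8 uM; on this read-out lower numbers stand for a weaker effect and higher numbers for a stronger effect at the one concentration tested. Among the measured compounds shown here, compound 2 gives 77.7%, the highest of the two numbers so far, and its nearest neighbour is compound 1 `CC1CCCCN1C(=S)SCc1ccc(C(=O)Nc2ccccc2N)cc1`, which in this assay gives 76.3%. For the measured compounds named here, the single measured step, a number 1.4 percentage points higher from compound 1 to compound 2 (within the scatter), came from exchanging one amine on the thiocarbonyl carbon for another and lies within the scatter.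

The next compound, compound 3 `CC1CCN(C(=S)SCc2ccc(C(=O)Nc3ccccc3N)cc2)CC1`, differs from compound 2 at the same place: 4-methylpiperidin-1-yl in place of ethyl((pyridin-4-yl)methyl)amino on a thiocarbonyl carbon. Both the leaving and the entering group sit on the thiocarbonyl carbon whose other neighbour is sulfur. Going by the values given here, the one step that bears on this change is a number 1.4 percentage points higher from compound 1 to compound 2 (within the scatter), which showed that swapping the amine on that carbon left the read-out unchanged within the scatter. Because compound 1, which already carries a methylpiperidinyl group at that position, gives 76.3%, compound 3 is expected to show a step of a number 1.7 percentage points lower from compound 2 to compound 3 (within the scatter) in this assay, not beyond the scatter. Compound 3 is therefore estimated at 76%, with a range from 64% to 86%.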

Compound 3, a percentage reported as inhibition, at one concentration (the size of the read-out at that concentration, not a potency): 72.5%
Estimate against measurement, compound 3: 3.5 percentage points above; the range from low to high includes it.
By their numbers in this assay, from the lowest: compounds 3, 1 and 2 (each within the scatter of the next).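

In this assay, the step of a number 5.2 percentage points lower from compound 2 to compound 3 (within the scatter) shows that this thiocarbonyl carbon tolerates a change of ring type as well as a change of amine: 4-methylpiperidin-1-yl, with its six-membered non-aromatic ring, takes the place of ethyl((pyridin-4-yl)methyl)amino, with its six-membered aromatic ring, and the difference stays within the scatter. Among the compounds shown here, the step of a number 3.8 percentage points lower from compound 1 to compound 3 (within the scatter) adds the first comparison of two methylpiperidinyl groups at this place, and it too stays within the scatter, so the read-out does not separate 4-methylpiperidin-1-yl from 2-methylpiperidin-1-yl. No measurement is available that would explain these results or link them to any property of the groups.

The compounds shown leave open whether a morpholine, a piperazine or an open-chain diethylamino group on the thiocarbonyl carbon would move the read-out beyond the scatter. On these data alone, it also remains open whether compounds that cannot be told apart at the single concentration tested would separate across a full concentration series, since a percentage at one concentration is not a potency.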